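A few compounds are considered here, and "the series" means these few. Any claim that something is new, unique, unknown or untested is made for them only; others in the source may bear on it.

Measured so far:
Compound 1 `COc1ccccc1/C=C1\CCC/C(=C\c2cccc(OC)c2OC)C1=O`: > 20000 nM
Compound 2 `COc1cc(/C=C2\CCC/C(=C\c3cccc(OC)c3OC)C2=O)ccc1O`: > 20000 nM

In a functional assay on A549 cells (Homo sapiens) for cytotoxicity, read by MTT assay, with a stated time of 72 h (on this read-out lower numbers stand for stronger inhibition and higher numbers for weaker inhibition), compound 2 gives > 20000 nM, which is a limit and not a number. Compound 1 likewise gives only a limit, > 20000 nM. The two compounds therefore share one boundary: the limit of > 20000 nM in this assay, at which 2 of the 2 values shown sit.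

Among the measured compounds shown here, the only measured step is a step that the two limits leave unreadable from compound 1 to compound 2. It places 4-hydroxy-3-methoxyphenyl in place of 2-methoxyphenyl and gives no size to carry forward.

Compound 3 `COc1cccc(/C=C2\CCC/C(=C\c3ccc(O)c(O)c3)C2=O)c1OC` differs from compound 2 by hydrogen in place of methyl on an oxygen on an aromatic ring, so that 4-hydroxy-3-methoxyphenyl becomes 3,4-dihydroxyphenyl. For the measured compounds named here, no measured step speaks directly to this change, so any expectation is loose. A modest move towards lower numbers is expected in this assay, though a reading that again stops at the limit would be no surprise. The expected change is an at least 1.4-fold lower number from compound 2 to compound 3 (0.15 log units; that floor lies within the scatter). For compound 3 the estimated value is 14000 nM, with an expected range from 4000 nM to 40000 nM.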

Compound 3, half-maximal inhibitory concentration: > 20000 nM
Compound 3: no number, only a limit; the forecaster's own chance of this, stated with the estimate: 55%; middle value at least 1.4-fold (0.15 log units) from the limit.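

Compound 3 also gives only a limit, so its steps from compound 1 and compound 2 cannot be read, and no new step emerges from this assay: the limit of > 20000 nM in this assay, at which 3 of the 3 values shown sit.

The compounds shown leave open whether exchanging methoxy for hydroxy, or 2-methoxyphenyl for 3,4-dihydroxyphenyl, changes the read-out at all, and where the true values of all three compounds lie.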